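Swapping the Aryl Amide: Compound 2 to Compound 3

A few compounds are considered here, and "the series" means these few. Any claim that something is new, unique, unknown or untested is made for them only; others in the source may bear on it.

Compound 1 `CCCN(CC[C@H]1CC[C@H](NC(=O)c2ccc3ccccc3n2)CC1)[C@H]1CCc2nc(N)sc2C1` and compound 2 `CCCN(CC[C@H]1CC[C@H](NC(=O)c2ccc(-n3ccnc3)cc2)CC1)[C@H]1CCc2nc(N)sc2C1` share one core and differ only in the aromatic group on the carbonyl carbon. In an assay on brain for displacement of a labelled ligand from D(3) dopamine receptor (Rattus norvegicus) (a higher number here means a weaker inhibitor, a lower number a stronger inhibitor), compound 1 gives 1.6 nM, and compound 2 gives 1.9 nM. Of the two numbers, compound 2 stands at the higher one, but the gap, a 1.2-fold higher number from compound 1 to compound 2 (0.07 log units; within the scatter), lies within the scatter. Compound 3 `CCCN(CC[C@H]1CC[C@H](NC(=O)c2cccc(-n3cncn3)c2)CC1)[C@H]1CCc2nc(N)sc2C1` carries the next change in the same place: 3-(1H-1,2,4-triazol-1-yl)phenyl in place of 4-(1H-imidazol-1-yl)phenyl on a carbonyl carbon. For the measured compounds named here, the only measured step that bears on this is the one from compound 1 to compound 2, which stayed within the scatter, so a swap of the aromatic group on the carbonyl carbon has so far left this assay essentially unchanged. Compound 3 is therefore expected to show a step of a 1.6-fold higher number from compound 2 to compound 3 (0.20 log units; within the scatter), not beyond the scatter. The estimate for compound 3 in this assay is 3 nM, with a range from 1 nM to 9 nM.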

Compound 3, inhibition constant: 3 nM
For compound 3 middle estimate and measured number coincide at the digits printed; the range from low to high includes it.
By their numbers in this assay, from the lowest: compounds 1, 2 and 3 (each within the scatter of the next).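

In this assay, 3-(1H-1,2,4-triazol-1-yl)phenyl in place of 4-(1H-imidazol-1-yl)phenyl gives a 1.6-fold higher number from compound 2 to compound 3 (0.20 log units; within the scatter) and thus stays within the scatter, even though the five-membered ring and its place on the phenyl ring change together. Set against quinolin-2-yl, the same group gives a 1.9-fold higher number from compound 1 to compound 3 (0.27 log units; within the scatter) and so also stays within the scatter, which means that all three aromatic groups on the carbonyl carbon now lie within the scatter of one another.

As far as these compounds go, what each of the two changes in the step to compound 3 contributes alone remains open, since they occur together. Also open, from the compounds shown here alone, is whether a non-aromatic group such as a piperidine, or a carboxylic acid on the phenyl ring, would keep the number in this range, and no supporting data explain why the numbers stay so close.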